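Swapping a Methyl for a Methylbenzyl on a Rhodanine-like Core

The source may report more compounds than this note shows. Statements on the series, on what has been measured and on what is new or still open speak of the compounds shown alone.

Of the compounds shown here, two have so far been tested in a functional assay on L1210 cells (Mus musculus) for cytotoxicity, read by cell counting, with a stated time of 2 days; a lower number here means a stronger inhibitor, a higher number a weaker inhibitor. Compound 1, with the structure `CCN1C(=O)S/C(=C\c2ccc(N)cc2)C1=O`, gives 82000 nM in this assay. Compound 2, `C=C(Br)C(=O)Nc1cccc(/C=C2\SC(=O)N(Cc3ccc(Cl)cc3)C2=O)c1`, gives 940 nM. Compound 1 therefore stands at the higher, weaker end of the two numbers measured, and the gap between compound 1 and compound 2 is far beyond the usual scatter. Compound 2 differs from compound 1 in several places at once, so it offers no clean one-step comparison.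

Compound 3, `Cc1ccc(CN2C(=O)S/C(=C\c3ccc(N)cc3)C2=O)cc1`, has not yet been measured. It keeps the core and the aminophenyl group of compound 1 and changes only one spot: 4-methylphenyl in place of methyl on a saturated chain carbon bound to an amide-type nitrogen in a ring

Because compound 1 sits at 82000 nM and compound 2, which also bears a six-membered aromatic ring in its larger side group, sits at 940 nM, a move toward a lower number seems plausible, though its size is uncertain. The step from compound 1 to compound 3 is expected to be a clear decrease, a 4.1-fold lower number from compound 1 to compound 3 (0.61 log units; beyond the scatter). Compound 3 is thus estimated at 20000 nM, with a range from 4000 nM to 80000 nM.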

Compound 3, half-maximal inhibitory concentration: 94000 nM
Compound 3: the middle estimate sits 4.7-fold (0.67 log units) below what was measured; measured number above the stated range.
By their numbers in this assay, from the lowest: compound 2; then compounds 1 and 3 (each within the scatter of the next).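

In this assay, putting 4-methylphenyl in place of methyl on a saturated chain carbon bound to an amide-type nitrogen in a ring gives a 1.1-fold higher number from compound 1 to compound 3 (0.06 log units; within the scatter), so the two numbers cannot be told apart. Going by these compounds alone, this is the first clean one-step reading at this position, and it shows that a single carbon can give way to a much larger group carrying a six-membered aromatic ring with no measurable difference in this cell-counting read-out, while the rest of the molecule stays the same. No measurement on hand offers an explanation for this result.

From the compounds shown here alone, the finding covers only methyl and 4-methylphenyl at this place, so it remains open whether a group of a different kind, such as a carboxylic acid, an amine or a longer chain, would give a number that stands apart from these two. Going by these compounds, it also remains open whether 4-methylphenyl and methyl would still match if the aminophenyl group on the shared core were replaced by something else.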